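The source may report more compounds than this note shows. Statements on the series, on what has been measured and on what is new or still open speak of the compounds shown alone.

Compound 1 `Cc1ccc(OCC(=O)NNC(=O)c2cc3ccccc3oc2=O)c(C(=O)c2ccccc2Cl)c1` gives 54800 nM in a functional assay on DLA cells (Mus musculus) for cytotoxicity, read by trypan blue exclusion, with a stated time of 48 h; on this read-out higher numbers stand for weaker inhibition and lower numbers for stronger inhibition.
Compound 2 `Cc1ccc(OCC(=O)NNC(=O)c2cc3ccccc3oc2=O)c(C(=O)c2ccc(Cl)cc2)c1` gives 61600 nM in this assay.

In this assay compound 2 shows the higher of the two numbers measured, but its gap to compound 1 lies within the scatter. Compound 3 `Cc1ccc(C(=O)c2cc(C)ccc2OCC(=O)NNC(=O)c2cc3ccccc3oc2=O)cc1` has not yet been measured; it differs from compound 2 by methyl in place of chloro on an aromatic carbon. Among the compounds with values here, the only measured step, a 1.1-fold higher number from compound 1 to compound 2 (0.05 log units; within the scatter), moved the chloro group rather than replacing it, so it bears only loosely on this change and was itself within the scatter. No step beyond the scatter is therefore expected. Compound 3 is estimated at 60000 nM, with a range from 25000 nM to 150000 nM. This corresponds to an expected 1.0-fold lower number from compound 2 to compound 3 (0.01 log units; within the scatter).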

Compound 3, half-maximal inhibitory concentration: 87300 nM
The estimate for compound 3 lay 1.5-fold (0.16 log units) below the measured number; low and high end bracket the measured number.
By their numbers in this assay, from the lowest: compounds 1, 2 and 3 (each within the scatter of the next).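

Replacing the chloro group itself with methyl, on an aromatic carbon para to a large group, gives a 1.4-fold higher number from compound 2 to compound 3 (0.15 log units; within the scatter) in this assay, so this position tolerates this exchange without a step beyond the scatter. Going from the 2-chlorophenyl group to the 4-methylphenyl group gives a 1.6-fold higher number from compound 1 to compound 3 (0.20 log units; within the scatter), so the three compounds cannot be told apart in this assay. No measurement is available that would explain these numbers. As far as these compounds go, whether an amine, a carboxylic acid or a longer chain at this position would move the number beyond the scatter remains open.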